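Swapping a fluoro for a methoxy on the amide aryl ring

This account rests on a few compounds, and the source may have more. Where it says the series, first, only, none or still open, it means among the compounds named here.

Of the compounds shown here, three sharing one core have been measured in an assay on cells for displacement of a labelled ligand from Neuronal acetylcholine receptor; alpha3/beta4 (Homo sapiens); on this read-out lower numbers stand for stronger inhibition and higher numbers for weaker inhibition. Compound 1, `COc1ccc(NC(=O)c2cncc(N3CC4CC(C3)N4)c2)cc1OC`, gives 516 nM. Compound 2, `O=C(Nc1ccc(F)cc1F)c1cncc(N2CC3CC(C2)N3)c1`, gives 50 nM, and compound 3, `O=C(Nc1ccc(F)cc1)c1cncc(N2CC3CC(C2)N3)c1`, gives 81 nM. Among these three numbers compound 3 stands second highest: its neighbour is compound 2, and the only single-point step available, a 1.6-fold higher number from compound 2 to compound 3 (0.21 log units; within the scatter), stays within the scatter. Compound 1, by contrast, sits well above compound 3, beyond the scatter.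

Compound 4, `COc1cccc(NC(=O)c2cncc(N3CC4CC(C3)N4)c2)c1`, is not yet measured. It differs from compound 3 in one place: 3-methoxyphenyl in place of 4-fluorophenyl on an amide-type nitrogen. Within the data shown here, no measured step exchanges a fluoro for a methoxy directly, so the expectation leans on compound 1, whose ring on the amide-type nitrogen also carries methoxy groups and whose value 516 nM is the highest seen. A single methoxy may lie between. Compound 4 is therefore expected to show a higher number than compound 3 in this assay, an estimated step of a 2.5-fold higher number from compound 3 to compound 4 (0.39 log units; beyond the scatter), with compound 4 estimated at 200 nM, within a range from 80 nM to 500 nM.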

Compound 4, inhibition constant: 265 nM
Beside the measured number, compound 4's estimate is 1.3-fold (0.12 log units) below it; measured number inside the range.
By their numbers in this assay, from the lowest: compounds 2 and 3 (each within the scatter of the next); then compounds 4 and 1 (each within the scatter of the next).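

In this assay, among these compounds, this is the first direct exchange at the amide-type nitrogen of a fluorinated ring for a methoxy-bearing one, and 3-methoxyphenyl in place of 4-fluorophenyl gives a 3.3-fold higher number from compound 3 to compound 4 (0.51 log units; beyond the scatter). Set against the 2,4-difluorophenyl ring, the same group gives a 5.3-fold higher number from compound 2 to compound 4 (0.72 log units; beyond the scatter), so both exchanges move the number beyond the scatter and towards weaker inhibition. Taking away the second methoxy gives a 1.9-fold lower number from compound 1 to compound 4 (0.29 log units; within the scatter), so one methoxy and two cannot be told apart here, and among these four compounds the two fluorinated rings give the lower numbers, with none going against this.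

Nothing at hand explains this gap. Open, as far as these compounds go, is whether the number follows the methoxy itself or its place on the ring, which 3-fluorophenyl and 4-methoxyphenyl would separate, and how a 3-aminophenyl ring would read.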